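A Methyl Group Added to a Simple Phenyl Lactone

A few compounds are considered here, and "the series" means these few. Any claim that something is new, unique, unknown or untested is made for them only; others in the source may bear on it.

Of the compounds shown here, three built on one shared unsaturated lactone core have been measured in a functional assay on Jurkat cells (Homo sapiens) for inhibition, read by ELISA, with a stated time of 13 h; on this read-out higher numbers stand for weaker inhibition and lower numbers for stronger inhibition. Compound 1 `O=C1C=CCC(c2cc3ccccc3o2)O1` gives 66.9 nM, compound 2 `O=C1C=CCC(c2csc3ccccc23)O1` gives 908 nM, and compound 3 `O=C1C=CCC(c2ccccc2)O1` gives 166 nM. On these numbers compound 3 stands second highest of the three. Its nearest neighbour is compound 1, whose number is lower by a margin beyond the scatter, so compound 1 inhibits more strongly; furthest from it lies compound 2, whose number is higher by a margin that is also beyond the scatter, so compound 2 inhibits more weakly than compound 3.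

Compound 4 `Cc1ccc(C2CC=CC(=O)O2)cc1` has not yet been measured in this assay. It differs from compound 3 in one place: methyl in place of hydrogen on an aromatic carbon. Within the data shown here, no pair of measured compounds shows this particular change, so its effect cannot be read from the numbers in hand. The change adds only a single carbon, and the step from compound 3 to compound 4 in this assay is expected to be a 1.3-fold lower number from compound 3 to compound 4 (0.11 log units; within the scatter), a small move at most, lying within the usual scatter. For compound 4 the estimated value in this assay is 130 nM, with an expected range from 50 nM to 350 nM.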

Compound 4, half-maximal inhibitory concentration: 142 nM
For compound 4 the middle estimate is 1.1-fold (0.04 log units) below the measured one, within the range that was stated.
By their numbers in this assay, from the lowest: compound 1; then compounds 4 and 3 (each within the scatter of the next); then compound 2.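

In this assay, methyl in place of hydrogen on an aromatic carbon, para to a group of 7 heavy atoms, gives a 1.2-fold lower number from compound 3 to compound 4 (0.07 log units; within the scatter), so the two compounds cannot be told apart on this read-out. Among these compounds, this is the first pair in the set that differs in one place only, and it shows that this position of the six-membered aromatic ring can carry one added carbon with no change in inhibition beyond the scatter. Nothing measured here gives a reason for this result.

On these data alone, a single small group says little about what this position will accept, so it remains open whether a longer chain such as propyl, a carboxylic acid or an amine placed here would also leave the number within the scatter or would move it clearly in either direction. The compounds shown also leave open whether methyl on the other carbons of this ring would behave as it does here, and whether the same change would give a similar result on the aromatic groups of compound 1 and compound 2.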